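The compounds below may be only part of what the source reports. "The series", "measured", "known", "first", "only" and "open" are said of these compounds alone.

Working notes on the shared core of compound 1 `C=CC1=C(C(=O)NCCC)C(c2ccc(F)cc2)OC1`. In a functional assay on A549 cells (Homo sapiens) for cytotoxicity, read by MTT assay, with a stated time of 24 h (a lower number here means a stronger inhibitor, a higher number a weaker inhibitor), compound 1 gives > 100000 nM, which is a limit of the assay. Compound 2 `C=CC1=C(C(=O)NCC(C)C)C(c2ccc(F)cc2)OC1` carries methyl in place of hydrogen on a saturated chain carbon bound to two saturated chain carbons. In this assay compound 2 gives > 100000 nM, again a limit. The step that the two limits leave unreadable from compound 1 to compound 2 cannot be sized because of the limit of > 100000 nM in this assay, at which 3 of the 3 values shown sit. Compound 3 `C=CC1=C(C(=O)NCCC)C(c2ccc(OC)cc2)OC1` differs from compound 1, and so do the two cores, by methoxy in place of fluoro on an aromatic carbon. In this assay compound 3 gives > 100000 nM, a limit once more, so a step that the two limits leave unreadable from compound 1 to compound 3 is also unreadable. Compound 4 `C=CC1=C(C(=O)NCC(C)C)C(c2ccc(OC)cc2)OC1` is not yet measured; it differs from compound 3 by methyl in place of hydrogen on a saturated chain carbon bound to two saturated chain carbons, the same change as from compound 1 to compound 2, at the same place. Compound 4 is expected to sit at the limit as well, an estimated step that the limit leaves unreadable from compound 3 to compound 4. The estimate for compound 4 is 150000 nM, expected between 60000 nM and 400000 nM.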

Compound 4, half-maximal inhibitory concentration: > 100000 nM
Compound 4 gave a limit, no number (the forecaster's own chance of this, stated with the estimate: 85%); the middle value is on the limit's open side.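

Among the compounds shown here, compound 4 gives only a limit, so no step from compound 3 or compound 2 to it can be read: the limit of > 100000 nM in this assay, at which 4 of the 4 values shown sit. The compounds shown leave open whether any change on the shared core brings a measurable value.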